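The compounds below may be only part of what the source reports. "The series", "measured", "known", "first", "only" and "open" are said of these compounds alone.

In a functional assay on LOX IMVI cells (Homo sapiens) for cytotoxicity, read by MTT assay, with a stated time of 24 h (a lower number here means a stronger inhibitor, a higher number a weaker inhibitor), compound 1 `O=S(=O)(NCCCNc1nccc(-c2[nH]c(-c3ccccc3)nc2-c2ccc(Cl)c(O)c2)n1)c1ccccc1` gives 2630 nM as its result. Compound 2 `O=S(=O)(NCCCNc1nccc(-c2[nH]c(-c3ccccc3)nc2-c2ccc(Cl)c(O)c2)n1)c1ccc(C(F)(F)F)cc1` gives 10100 nM and so holds the higher of the two numbers, which makes it the weaker inhibitor of this pair. Going by the values given here, the single measured step is a 3.8-fold higher number from compound 1 to compound 2 (0.58 log units; beyond the scatter) on putting trifluoromethyl in place of hydrogen on an aromatic carbon. Compound 3 `COc1ccc(S(=O)(=O)NCCCNc2nccc(-c3[nH]c(-c4ccccc4)nc3-c3ccc(Cl)c(O)c3)n2)cc1` awaits measurement. Its difference from compound 2 is methoxy in place of trifluoromethyl on an aromatic carbon in one place: methoxy in place of trifluoromethyl on an aromatic carbon. Among the compounds with values here, this removes the group added in the step to compound 2, so a move back toward compound 1 at 2630 nM in this assay is expected, though no measured compound carries methoxy and the size of the return is uncertain. The expected change is a 2.9-fold lower number from compound 2 to compound 3 (0.46 log units; beyond the scatter) toward a lower number and stronger inhibition. For compound 3 the estimated value is 3500 nM with an expected range from 1300 nM to 9000 nM as the likely span.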

Compound 3, half-maximal inhibitory concentration: 36800 nM
The estimate for compound 3 lay 11-fold (1.02 log units) below the measured number; measured number above the stated range.
By their numbers in this assay, from the lowest: compound 1; then compound 2; then compound 3.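

In this assay, swapping trifluoromethyl for methoxy on the six-membered aromatic ring, para to a large group, gives a 3.6-fold higher number from compound 2 to compound 3 (0.56 log units; beyond the scatter), so removing trifluoromethyl does not by itself restore the number seen with hydrogen. Set against hydrogen, methoxy gives a 14-fold higher number from compound 1 to compound 3 (1.15 log units; beyond the scatter), so among these three compounds both substituents at this position go with weaker inhibition than hydrogen, and methoxy goes with the weaker of the two results. Nothing available here explains why these two groups differ or why either raises the number.

Still open is whether any group at this position can match or better hydrogen, since only two substituents are shown. A fluorine atom, an amine or a carboxylic acid in the same place would test whether the rise in the number holds beyond trifluoromethyl and methoxy.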